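A few compounds are considered here, and "the series" means these few. Any claim that something is new, unique, unknown or untested is made for them only; others in the source may bear on it.

Measured so far in a functional assay on MDA-MB-435 cells (Homo sapiens) for inhibition, read by sulforhodamine B assay, with a stated time of 48 h; on this read-out higher numbers stand for weaker inhibition of growth and lower numbers for stronger inhibition of growth:
Compound 1 `Cc1ccc(C2=NN(c3ccc(S(C)(=O)=O)cc3)C(=O)CC2)cc1`: 390 nM
Compound 2 `Cc1cc(O)ccc1C1=NN(c2ccc(S(C)(=O)=O)cc2)C(=O)CC1`: 5830 nM

Compound 2, at 5830 nM, has the higher of the two numbers, so it is the weaker growth inhibitor of the pair. The next structure is compound 3 `CCc1ccc(C2=NN(c3ccc(S(C)(=O)=O)cc3)C(=O)CC2)cc1`, and the change is 4-ethylphenyl in place of 4-hydroxy-2-methylphenyl on a carbon with a double bond to nitrogen. In words, 4-ethylphenyl takes the place of 4-hydroxy-2-methylphenyl on a carbon with a double bond to nitrogen.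

For the measured compounds named here, only one measured step bears on this change: a 15-fold higher number from compound 1 to compound 2 (1.17 log units; beyond the scatter). It is large and lies beyond the usual scatter. Compound 1, at 390 nM, carries 4-methylphenyl, the closest measured match to 4-ethylphenyl. A large step to a lower number is therefore expected in this assay, of about the size of the measured step in reverse. Going by the values given here, this expectation rests on a single pair, and no measured compound carries the ethyl group, so the range is wide. The estimated change is a 13-fold lower number from compound 2 to compound 3 (1.11 log units; beyond the scatter). For compound 3 the estimated value is 450 nM, with an expected range from 130 nM to 1500 nM.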

Compound 3, concentration for total growth inhibition: 740 nM
The estimate for compound 3 lay 1.6-fold (0.22 log units) below the measured number, and the stated range covers the measured number.
By their numbers in this assay, from the lowest: compounds 1 and 3 (each within the scatter of the next); then compound 2.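

In this assay, putting 4-ethylphenyl in place of 4-hydroxy-2-methylphenyl gives a 7.9-fold lower number from compound 2 to compound 3 (0.90 log units; beyond the scatter), so a second group without the hydroxyl recovers much of the growth inhibition lost in compound 2. Extending the methyl of compound 1 to the ethyl of compound 3 gives a 1.9-fold higher number from compound 1 to compound 3 (0.28 log units; within the scatter), and because this step lies within the scatter, the assay does not separate the two compounds, so at this position on a carbon with a double bond to nitrogen, the extra chain carbon shows no clear effect. Nothing measured here explains why the group in compound 2 goes with the higher number.

Compound 2 differs from compounds 1 and 3 by carrying both a hydroxyl and a methyl at different ring positions, so the compounds shown cannot say how much of the gap belongs to each. Also open, going by these compounds, is how this assay would read a 4-hydroxyphenyl, 4-methoxyphenyl or 4-aminophenyl group, or a longer chain such as 4-propylphenyl, in the same place.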